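Chain-terminal fluoroalkyl variation in a dual-phenol thiochromane acid series

The source may hold more compounds than are shown below. What is called first, only, known or untested is meant among the compounds shown, and "the series" means these compounds.

Measured so far in a functional assay on the whole organism for antagonist activity, with Mus musculus as the target, at a dose of 30 mg/kg by the oral route; on this read-out higher numbers stand for a stronger effect at the one dose given and lower numbers for a weaker effect:
- compound 1, `C[C@]1(c2ccc(O)cc2)CSc2cc(O)ccc2[C@H]1CCCCCCCCC(CCCC(F)(F)C(F)(F)F)C(=O)O`: 94%
- compound 2, `C[C@]1(c2ccc(O)cc2)CSc2cc(O)ccc2[C@H]1CCCCCCCC(CCCC(F)(F)C(F)(F)F)C(=O)O`: "not determined" (no result reported)
- compound 3, `C[C@]1(c2ccc(O)cc2)CSc2cc(O)ccc2[C@H]1CCCCCCCCC(CCC(F)(F)C(F)(F)C(F)(F)C(F)(F)F)C(=O)O`: 96%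

Compound 1 stands at the lower of the two numbers recorded, and its nearest neighbour is compound 3, whose value sits within the scatter of it; no order between them can be read. Compound 2 carries no number in this assay.

Compound 4, `C[C@]1(c2ccc(O)cc2)CSc2cc(O)ccc2[C@H]1CCCCCCCCC(CCCC(F)(F)C(F)(F)C(F)(F)C(F)(F)F)C(=O)O`, is the next member to be run. Relative to compound 1 the change is 1,1,2,2,2-pentafluoroethyl in place of fluoro on a saturated chain carbon bound to two fluorine atoms and a saturated chain carbon. Among the measured compounds shown here, no pair of measured compounds differs in one place, so no measured step is available for reference. Compound 1 and compound 3, which differ in the fluoroalkyl terminus and the chain between, read within the scatter of each other, so the expectation is that a longer perfluorinated end does not move the read-out beyond the scatter. For compound 4 the expected step of a number 1 percentage points higher from compound 1 to compound 4 (within the scatter) is accordingly small, with no direction beyond the scatter. Compound 4 is estimated at 95%, in the range 85% to 99%.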

Compound 4, a percentage reported as inhibition, in the whole organism at one dose (the size of the read-out at that dose, not a potency): 99%
Compound 4: the middle estimate sits 4 percentage points below what was measured, within the range that was stated.
By their numbers in this assay, from the lowest: compounds 1, 3 and 4 (each within the scatter of the next).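

In this assay, the place on a saturated chain carbon bound to two fluorine atoms and a saturated chain carbon now has its first step that differs in one place: 1,1,2,2,2-pentafluoroethyl in place of fluoro gives a number 5 percentage points higher from compound 1 to compound 4 (within the scatter). At the one oral dose given, this position therefore accepts seven heavy atoms where there was one, and the read-out does not move beyond the scatter. The compounds shown offer no measurement that could account for the step.

From the compounds shown here alone, whether an ethyl group or a terminal amine at this place would hold the read-out as high remains open. Also open, going by these compounds, is whether a lower dose would separate compound 1 from compound 4, since a single dose gives no potency.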